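The compounds below may be only part of what the source reports. "The series", "measured", "known", "first", "only" and "open" are said of these compounds alone.

Of the compounds shown here, three built on a shared core have been measured in an assay on cells for agonist activity at ecdysone receptor (Bombyx mori), read by a luciferase reporter, with a stated time of 24 h; a lower number here means that less compound is needed, a higher number that more compound is needed for the effect. Compound 1 `CC(C)(C)N(NC(=O)c1ccccc1)C(=O)c1ccccc1Br` gives 170 nM. Compound 2 `CC(C)(C)N(NC(=O)c1cccc(Cl)c1)C(=O)c1ccccc1Cl` gives 155 nM. Compound 3 `CC(C)(C)N(NC(=O)c1cccc(C#N)c1)C(=O)c1ccccc1Cl` gives 955 nM, the highest of the three numbers, lying beyond the scatter above both compound 1 and compound 2. For the measured compounds named here, the only single-point change among the measured compounds is a 6.2-fold higher number from compound 2 to compound 3 (0.79 log units; beyond the scatter), a modest rise.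

Compound 4 `Cc1ccc(C(=O)NN(C(=O)c2ccccc2Cl)C(C)(C)C)c(C)c1` has not yet been measured. It differs from compound 3 by 2,4-dimethylphenyl in place of 3-cyanophenyl on a carbonyl carbon. The step from compound 2 to compound 3 is the only measured one that touches this ring, and it showed that bringing in the cyano raised the number. In compound 4 the cyano leaves and a ring with two methyls enters, for which no direct measurement exists. The expectation therefore leans on compound 2, which gives 155 nM, and on compound 1, which gives 170 nM, both rings without a cyano. Compound 4 is expected to move back toward those numbers, a step of a 4.3-fold lower number from compound 3 to compound 4 (0.64 log units; beyond the scatter), giving an estimate of 220 nM within a range of 70 nM to 700 nM.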

Compound 4, half-maximal effective concentration: 162 nM
For compound 4 the middle estimate is 1.4-fold (0.13 log units) above the measured one; low and high end bracket the measured number.
By their numbers in this assay, from the lowest: compounds 2, 4 and 1 (each within the scatter of the next); then compound 3.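

The ring on this carbonyl carbon accepts 2,4-dimethylphenyl in place of 3-cyanophenyl, and this assay shows a 5.9-fold lower number from compound 3 to compound 4 (0.77 log units; beyond the scatter), so the number falls back once the nitrile has gone. The new ring also reads level with the chlorine-bearing ring, with a 1.0-fold higher number from compound 2 to compound 4 (0.02 log units; within the scatter), so 2,4-dimethylphenyl and 3-chlorophenyl cannot be told apart in this assay even though they carry different groups. No independent measurement is available to explain why the nitrile-bearing ring stands apart.

Going by these compounds, it remains open whether another group on this ring, such as an amine or a carboxylic acid, would stay with the lower numbers or sit with compound 3. It is also open whether either methyl of 2,4-dimethylphenyl matters alone, since a ring with a single methyl is not among these compounds.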